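The source may report more compounds than this note shows. Statements on the series, on what has been measured and on what is new or still open speak of the compounds shown alone.

Working notes on the series.

Compound 1 `Cc1nn(CC(=O)N2CCN(c3sc(C(F)(F)F)nc3-c3nc4ccccc4[nH]3)C[C@H]2C)cc1CN(C)C` is the reference point here. In a functional assay on Venous blood for antagonist activity at C-X-C chemokine receptor type 3 (Homo sapiens), read by flow cytometry, with a stated time of 30 min, in the presence of a further agent that is not named here (a lower number here means a stronger inhibitor, a higher number a weaker inhibitor), compound 1 gives 330 nM, the lowest of the two numbers recorded so far. Going by the values given here, compound 2 `Cc1nc(C)n(CC(=O)N2CCN(c3sc(C(F)(F)F)nc3-c3nc4ccc(C(C)(C)O)c(F)c4[nH]3)C[C@H]2C)n1` is the only other measured member; in this assay compound 2 gives 628 nM, which sits within the scatter of compound 1, so the two are not separated.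

Compound 3 `Cc1nc(C)n(CC(=O)N2CCN(c3sc(C(F)(F)F)nc3-c3nc4ccccc4[nH]3)C[C@H]2C)n1` has not yet been measured. It is reached from compound 1 by one change: 3,5-dimethyl-1H-1,2,4-triazol-1-yl in place of 4-((dimethylamino)methyl)-3-methyl-1H-pyrazol-1-yl on a saturated chain carbon bound to a carbonyl carbon. The group that enters is the same one carried by compound 2, while the rest of compound 3 matches compound 1. Among the compounds with values here, no measured pair differs in exactly this place, so the step is not anchored by a counterpart; the only guidance is that compound 2, which bears the entering group together with a further change elsewhere, reads close to compound 1.

The step from compound 1 to compound 3 is therefore expected to be small, at most a mild weakening, estimated as a 1.5-fold higher number from compound 1 to compound 3 (0.18 log units; within the scatter). In this assay compound 3 is expected to give 500 nM, with a range from 200 nM to 1400 nM.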

Compound 3, half-maximal inhibitory concentration: 237 nM
Beside the measured number, compound 3's estimate is 2.1-fold (0.32 log units) above it; the range from low to high includes it.
By their numbers in this assay, from the lowest: compounds 3, 1 and 2 (each within the scatter of the next, the first and the last beyond it).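

In this assay, the exchange of 4-((dimethylamino)methyl)-3-methyl-1H-pyrazol-1-yl for 3,5-dimethyl-1H-1,2,4-triazol-1-yl on a saturated chain carbon bound to a carbonyl carbon can now be read directly, and it gives a 1.4-fold lower number from compound 1 to compound 3 (0.14 log units; within the scatter), so compound 1 and compound 3 are not separated. For this pair, then, a group of 10 heavy atoms with two ring hetero atoms and a group of 7 heavy atoms with three ring hetero atoms read alike at this place, on the core shared by compound 1 and compound 3. No measurement at hand explains this equivalence.

The compounds shown leave open whether the same reading in this assay would hold for quite different groups at this place, such as a phenyl ring, a carboxylic acid or a longer chain ending in a primary amine. Also open, on these data alone, is how a pyrazole carrying only methyl groups would read, a comparison that would separate the dimethylaminomethyl group from the exchange of one ring for the other.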